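Swapping chloro for methyl at the para position

This account rests on a few compounds, and the source may have more. Where it says the series, first, only, none or still open, it means among the compounds named here.

Measured so far:
compound 1, `COC(=O)C(=O)/C=C(\O)c1ccccc1[N+](=O)[O-]`, 1%
compound 2, `O=C(O)C(=O)/C=C(\O)c1ccccc1`, 0%
compound 3, `COC(=O)C(=N)/C=C(\O)c1ccc(Cl)cc1`, 13%

Of the compounds shown here, three have been tested in an assay for inhibition of kynurenine 3-monooxygenase (Rattus norvegicus), tested at 10 uM; a higher number here means more inhibition at the concentration tested (going by the name of the read-out), a lower number less inhibition. Compound 1, `COC(=O)C(=O)/C=C(\O)c1ccccc1[N+](=O)[O-]`, gives 1%, and compound 2, `O=C(O)C(=O)/C=C(\O)c1ccccc1`, gives 0%. Compound 3, `COC(=O)C(=N)/C=C(\O)c1ccc(Cl)cc1`, gives 13%, the highest number of the three; its distance to compound 1 and to compound 2 lies beyond the usual scatter in each case, though all three numbers remain low for an assay of this kind.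

The next compound, compound 4, `COC(=O)C(=N)/C=C(\O)c1ccc(C)cc1`, differs from compound 3 in one place: methyl in place of chloro on an aromatic carbon. Among the compounds with values here, no pair of measured compounds shows the effect of such a change, and the shared core carrying this ring is otherwise unchanged. Because compound 3 gives only 13%, there is little room for a large fall, and nothing in the measured set points to a large rise either. The step of a number 3 percentage points lower from compound 3 to compound 4 (within the scatter) is expected to stay within the scatter. For compound 4 in this assay the estimate is 10%, with a likely range from 2% to 22%.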

Compound 4, a percentage reported as inhibition, at one concentration (the size of the read-out at that concentration, not a potency): 4%
The estimate for compound 4 lay 6 percentage points above the measured number; measured number inside the range.
By their numbers in this assay, from the lowest: compounds 2, 1, 4 and 3 (each within the scatter of the next, the first and the last beyond it).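

In this assay, within the data shown here, methyl in place of chloro on an aromatic carbon, para to a group of 9 heavy atoms, gives a number 9 percentage points lower from compound 3 to compound 4 (within the scatter) and is the first single-place change that can be read in this set. Both groups have 1 heavy atom, no ring, no hydrogen-bond donors or acceptors and no net charge, and at this position the reading does not separate them beyond the usual scatter of repeated measurements. Nothing available on these compounds offers an explanation of this result.

Going by these compounds, it remains open whether a different group at this position, such as an amine, a carboxylic acid, a methoxy group or a longer chain, would shift the number beyond the scatter. On these data alone, the same exchange of chloro for methyl on another core, or at another place on this ring, also remains open, so this single pair cannot be extended into a general rule.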